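Fluoro in Place of Methyl on Compound 3

The source may hold more compounds than are shown below. What is called first, only, known or untested is meant among the compounds shown, and "the series" means these compounds.

Measured in a functional assay on HeLa cells (Homo sapiens) for cytotoxicity, read by MTT assay, with a stated time of 2 days; a lower number here means a stronger inhibitor, a higher number a weaker inhibitor:
- Compound 1 `Cc1ccc2nc(-c3ccccc3N(C)C)[nH]c(=O)c2c1`: 14000 nM
- Compound 2 `CN(C)c1ccc2nc(-c3cccc4ccccc34)[nH]c(=O)c2c1`: 50 nM
- Compound 3 `Cc1ccc2c(=O)[nH]c(-c3ccccc3C)nc2c1`: > 50000 nM (a limit, not a number)

These three compounds share a core but carry different groups, and their readings spread widely. In this assay compound 2 gives 50 nM, while compound 1 gives 14000 nM. A lower number marks the stronger inhibitor of cell growth.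

Compound 3 reads > 50000 nM, and this reading is a limit. It gives a bound, not an exact place on the scale: the limit of > 50000 nM in this assay, at which 1 of the 3 values shown sits.

The next compound, compound 4 `Cc1ccc2c(=O)[nH]c(-c3ccccc3F)nc2c1`, carries fluoro in place of methyl on an aromatic carbon. The group sits on a six-membered aromatic ring of carbon only, ortho to a large group. Among the measured compounds shown here, no measured pair here shows what this exchange does, so any expectation is loose.

The expectation starts from compound 3, whose reading of > 50000 nM is a limit. In this assay the estimated step of an at least 1.2-fold lower number from compound 3 to compound 4 (0.09 log units; that floor lies within the scatter) is expected to be small, toward a lower number or none beyond the usual scatter. A limit may well be reported again.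

For compound 4 the estimated value is 40000 nM, with an expected range of 10000 nM to 100000 nM.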

Compound 4, half-maximal inhibitory concentration: 830 nM
Compound 4: middle estimate off by 48-fold (1.68 log units), on the high side, and the stated range ends above it.
By their numbers in this assay, from the lowest: compound 2; then compound 4; then compound 1. At a limit, above all of these: compound 3.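

In this assay, fluoro in place of methyl on this aromatic carbon, ortho to a large group, gives an at least 60-fold lower number from compound 3 to compound 4 (1.77 log units; beyond the scatter). Among the compounds shown here, the earlier compounds offered no pair differing in one place, so this is the first direct sign that the position responds strongly to a single exchange, one that swaps one heavy atom for another and leaves the counts of hydrogen-bond donors and acceptors and the net charge unchanged. The reading of compound 3 is a limit, so the step is a floor and not an exact size: the limit of > 50000 nM in this assay, at which 1 of the 4 values shown sits.

A single exchange at a single position cannot separate what fluoro adds from what the loss of methyl removes, so the reason for the step stays open. Chloro, methoxy or an amine on the same aromatic carbon would show whether the lower number belongs to fluoro alone or is shared by other groups, and it also remains open whether the same exchange would have a similar effect on a core carrying different groups elsewhere.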